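Anilide substituent series: fluoro to butyl on the aryl ring

The source may hold more compounds than are shown below. What is called first, only, known or untested is meant among the compounds shown, and "the series" means these compounds.

Compound 1 `O=C(CSC(=S)N[C@H]1CCOC1=O)Nc1ccccc1`: in a functional assay on MCF7 cells (Homo sapiens) for cytotoxicity, read by MTT assay, with a stated time of 72 h (on this read-out lower numbers stand for stronger inhibition and higher numbers for weaker inhibition), compound 1 gives > 128000 nM, a limit of the assay.
Compound 2 `O=C(CSC(=S)N[C@H]1CCOC1=O)Nc1ccc(F)cc1`: in this assay compound 2 gives 5830 nM.

Among the measured compounds shown here, compound 2 holds the only number measured in this assay. Compound 1 sits at the limit of > 128000 nM in this assay, at which 1 of the 2 values shown sits. Compound 3 `CCCCc1ccc(NC(=O)CSC(=S)N[C@H]2CCOC2=O)cc1` differs from compound 2 by butyl in place of fluoro on an aromatic carbon. For the measured compounds named here, the single measured step, an at least 21-fold lower number from compound 1 to compound 2 (1.34 log units; beyond the scatter), changed the same aromatic carbon and was large, yet it exchanged hydrogen for fluoro rather than fluoro for butyl, so it gives little guidance on direction. The step expected here is a 1.5-fold higher number from compound 2 to compound 3 (0.19 log units; within the scatter), not beyond the scatter. For compound 3 the estimate in this assay is 9000 nM, ranging from 2500 nM to 40000 nM.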

Compound 3, half-maximal inhibitory concentration: 40200 nM
Compound 3: middle estimate off by 4.5-fold (0.65 log units), on the low side; the measured number lies above the stated range.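

In this assay, the aromatic carbon does not respond to every group alike: butyl in place of fluoro gives a 6.9-fold higher number from compound 2 to compound 3 (0.84 log units; beyond the scatter), so the gain seen with fluoro is only partly kept. Butyl in place of hydrogen still gives an at least 3.1-fold lower number from compound 1 to compound 3 (0.50 log units; beyond the scatter), so both groups read lower than hydrogen at this carbon, with fluoro the lowest of the three. Compound 1 holds a limit of the assay and not a number: the limit of > 128000 nM in this assay, at which 1 of the 3 values shown sits.

As far as these compounds go, whether the number climbs with chain length or depends on something else about the group stays open. Methyl, a longer chain, an amine or a carboxylic acid on this carbon would help separate these readings.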